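Replacing formyl with 2-benzoylethenyl in compound 3

This account rests on a few compounds, and the source may have more. Where it says the series, first, only, none or still open, it means among the compounds named here.

Measured in a functional assay on NALM-6 cells (Homo sapiens) for cytotoxicity, with a stated time of 72 h; on this read-out lower numbers stand for an effect already at smaller amounts and higher numbers for an effect only at larger amounts of compound:
- compound 1 `C=C[C@](C)(CCCC(C)C)CCc1ccc(O)cc1`: 27500 nM
- compound 2 `C=C[C@@](C)(/C=C/c1ccc(O)cc1)CCC=O`: > 43400 nM (a limit)
- compound 3 `COc1ccc(/C=C/[C@@](C)(/C=C/c2ccc(O)c(C=O)c2)CCC=C(C)C)cc1`: > 43400 nM (a limit)

Compound 3 has no numerical value, only a limit. It sits at the limit of > 43400 nM in this assay, at which 2 of the 3 values shown sit. Among the compounds with values here, compound 1 27500 nM is the only compound here with a number.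

Compound 4 `COc1ccc(/C=C/[C@@](C)(/C=C/c2ccc(O)c(/C=C/C(=O)c3ccccc3)c2)CCC=C(C)C)cc1` differs from compound 3 at one place, on an aromatic carbon, ortho to a hydroxy group: 2-benzoylethenyl stands in place of formyl, (2-benzoylethenyl in place of formyl on an aromatic carbon).

Within the data shown here, no measured pair in this assay gauges this change, so the expectation is a loose one. A moderate move toward lower numbers is expected, since compound 1 at 27500 nM shows that the assay can return a number in this series. The expected change is an at least 2.4-fold lower number from compound 3 to compound 4 (0.38 log units; beyond the scatter). For compound 4 the estimate is 18000 nM, with an expected range of 5000 nM to 43400 nM. A further limit instead of a number remains a real possibility.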

Compound 4, half-maximal effective concentration: > 43400 nM
Compound 4: a limit, no number; the forecaster's own chance of this, stated with the estimate: 35%; middle value at least 2.4-fold (0.38 log units) from the limit.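

In this assay compound 3 and compound 4 both return only limits, not numbers, so no step can be read between them. On these data alone, whether 2-benzoylethenyl in place of formyl on an aromatic carbon shifts the read-out at all, and in which direction, stays open.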